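This account rests on a few compounds, and the source may have more. Where it says the series, first, only, none or still open, it means among the compounds named here.

Measured so far:
compound 1 `NS(=O)(=O)c1ccc(/C=C/c2ccc(O)c(O)c2)cc1`: 9160 nM
compound 2 `NS(=O)(=O)c1ccc(/C=C/c2ccc(F)cc2)cc1`: 42300 nM
compound 3 `NS(=O)(=O)c1ccc(/C=C/c2ccc(O)cc2)cc1`: 7090 nM

In a functional assay on RPMI-8226 cells (Homo sapiens) for inhibition (a higher number here means a weaker inhibitor of growth, a lower number a stronger inhibitor of growth), compound 3 sits at the low end of the three numbers. Its nearest neighbour gives a 1.3-fold lower number from compound 1 to compound 3 (0.11 log units; within the scatter), while its furthest neighbour gives a 6.0-fold lower number from compound 2 to compound 3 (0.78 log units; beyond the scatter).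

The next compound, compound 4 `CN(C)c1ccc(/C=C/c2ccc(S(N)(=O)=O)cc2)cc1`, has dimethylamino in place of hydroxy on an aromatic carbon, para to a large group: dimethylamino in place of hydroxy on an aromatic carbon. Going by the values given here, no measured step makes this exact change, so the evidence is indirect. Among the compounds with values here, two steps bear on it. The exchange at the same place, a 6.0-fold lower number from compound 2 to compound 3 (0.78 log units; beyond the scatter), shows that the group there can shift the number in this assay, and it sets a rough scale for the upper end of the range. The other step, a 1.3-fold lower number from compound 1 to compound 3 (0.11 log units; within the scatter), involves a hydroxy on the same ring and shows no change beyond the scatter. With only these two steps, neither the size nor the direction of the change is firmly fixed. As far as these compounds go, a small move toward a higher number seems the likeliest outcome, and a move beyond the scatter in either direction remains open.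

The expected result is a 1.3-fold higher number from compound 3 to compound 4 (0.10 log units; within the scatter). For compound 4 the estimated value is 9000 nM, with an expected range from 2500 nM to 32000 nM.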

Compound 4, concentration for 50% growth inhibition: 11600 nM
Compound 4: the middle estimate sits 1.3-fold (0.11 log units) below what was measured; the measured number falls inside the stated range.
By their numbers in this assay, from the lowest: compounds 3, 1 and 4 (each within the scatter of the next); then compound 2.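

In this assay, dimethylamino in place of hydroxy gives a 1.6-fold higher number from compound 3 to compound 4 (0.21 log units; within the scatter). At this aromatic carbon, para to a large group, a substituent with 3 heavy atoms and 0 hydrogen-bond donors therefore cannot be told apart from one with 1 heavy atom and 1 hydrogen-bond donor, so the hydrogen-bond donor of hydroxy is not required to keep the number in this range. Fluoro remains the substituent that stands apart among these para-substituted compounds, since dimethylamino in its place gives a 3.6-fold lower number from compound 2 to compound 4 (0.56 log units; beyond the scatter), the same direction as a 6.0-fold lower number from compound 2 to compound 3 (0.78 log units; beyond the scatter), and the data offer no measured explanation for either step.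

The compounds shown leave open whether a methoxy group or an unsubstituted amino group at this place would stay with hydroxy and dimethylamino or move toward fluoro, and so which feature separates fluoro from the other two. They also leave open whether a larger substituent such as diethylamino or morpholine would stay within the scatter of dimethylamino, or whether the tolerance seen so far has a limit.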